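This account rests on a few compounds, and the source may have more. Where it says the series, first, only, none or still open, it means among the compounds named here.

Measured compounds:
- compound 1, `C=CC(=O)Nc1cccc(NC(=O)CSc2nc(Nc3ccccc3)c3ccccc3n2)c1`, 10200 nM
- compound 2, `C=CC(=O)Nc1cccc(NC(=O)CSc2nc(Nc3ccc(F)cc3)c3ccccc3n2)c1`, 9490 nM
- compound 3, `C=CC(=O)Nc1cccc(NC(=O)CSc2nc(Nc3ccc(Cl)c(Cl)c3)c3ccccc3n2)c1`, 17700 nM

These three share one core and differ only in the ring attached to a nitrogen on an aromatic ring. In a functional assay on MDA-MB-231 cells (Homo sapiens) for inhibition, read by MTT assay, with a stated time of 72 h (on this read-out higher numbers stand for weaker inhibition and lower numbers for stronger inhibition), compound 3 gives the highest of the three numbers, yet its steps to the others, a 1.7-fold higher number from compound 1 to compound 3 (0.24 log units; within the scatter) and a 1.9-fold higher number from compound 2 to compound 3 (0.27 log units; within the scatter), both fall within the scatter, as does a 1.1-fold lower number from compound 1 to compound 2 (0.03 log units; within the scatter). So far, then, nothing on this ring has moved the read-out beyond the scatter.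

Compound 4, `C=CC(=O)Nc1cccc(NC(=O)CSc2nc(Nc3ccc(Cl)cc3Cl)c3ccccc3n2)c1`, keeps the same atoms as compound 3 and rearranges them: 2,4-dichlorophenyl in place of 3,4-dichlorophenyl on a nitrogen on an aromatic ring. Within the data shown here, no measured step exchanges one dichlorophenyl for another, so the nearest guides are the three small steps above, all within the scatter. On that basis no step beyond the scatter is expected in this assay, and compound 4 is estimated at 17000 nM, within a range of 6000 nM to 45000 nM, which means an expected step of a 1.0-fold lower number from compound 3 to compound 4 (0.02 log units; within the scatter).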

Compound 4, half-maximal inhibitory concentration: 23100 nM
Compound 4: the middle estimate sits 1.4-fold (0.13 log units) below what was measured; measured number inside the range.
By their numbers in this assay, from the lowest: compounds 2, 1, 3 and 4 (each within the scatter of the next, the first and the last beyond it).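

Moving one chlorine on this ring changes little in this assay (a 1.3-fold higher number from compound 3 to compound 4 (0.12 log units; within the scatter)), so the two dichlorophenyl compounds cannot be told apart here. Unlike the earlier steps, two steps on this ring now pass beyond the scatter, both modest and both toward weaker inhibition (a 2.4-fold higher number from compound 2 to compound 4 (0.39 log units; beyond the scatter) and a 2.3-fold higher number from compound 1 to compound 4 (0.36 log units; beyond the scatter)), although compound 3, which also carries two chlorines, stays within the scatter of compound 1 and compound 2, so this holds for compound 4 alone. Nothing measured here accounts for these steps.

All four compounds carry either a bare phenyl or a halogen-bearing phenyl on this nitrogen, and every number remains high. Going by these compounds, whether a methoxy group or an amine on the ring, or a benzyl or cyclohexyl group in its place, would give stronger inhibition stays open.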